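The source may hold more compounds than are shown below. What is called first, only, known or untested is meant among the compounds shown, and "the series" means these compounds.

Among the measured compounds shown here, compound 1, with the structure `O=C(Nc1nc(-c2ccc(Br)cc2)cs1)c1ccccc1`, is one of three compounds measured in a functional assay on MDA-MB-231 cells (Homo sapiens), read by microscopy and transwell migration, with a stated time of 24 h (a higher number here means a weaker inhibitor, a lower number a stronger inhibitor), where compound 1 gives 9500 nM. Compound 3, with the structure `CN(C(=O)c1ccccc1)c1nc(-c2ccc(Br)cc2)cs1`, shares the whole of that framework and differs from compound 1 by a single change, (methyl in place of hydrogen on an amide-type nitrogen). In this assay compound 3 gives 317 nM, and the step is a 30-fold lower number from compound 1 to compound 3 (1.48 log units; beyond the scatter).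

Compound 2, with the structure `Cc1sc(NC(=O)c2ccccc2)nc1-c1ccc(F)cc1`, is built on a different core; how its core differs from that of compound 1 is not broken down here. In this assay compound 2 gives 9100 nM, a number that sits within the usual scatter of the number for compound 1.

Compound 4, with the structure `Cc1sc(N(C)C(=O)c2ccccc2)nc1-c1ccc(F)cc1`, has not yet been measured. It stands to compound 2 as compound 3 stands to compound 1, with the difference (methyl in place of hydrogen on an amide-type nitrogen). The place of this change, an amide-type nitrogen whose other neighbours are an aromatic carbon and a carbonyl carbon, is described in the same words for both pairs, so it is the same change made on a second core. The step from compound 2 to compound 4 in this assay is expected to be a 28-fold lower number from compound 2 to compound 4 (1.45 log units; beyond the scatter), beside the measured 30-fold lower number from compound 1 to compound 3 (1.48 log units; beyond the scatter), and this rests on that single measured step only. On that basis compound 4 is estimated at 320 nM, with a range from 110 nM to 950 nM, pending the actual measurement.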

Compound 4, half-maximal inhibitory concentration: 1620 nM
The estimate for compound 4 lay 5.1-fold (0.70 log units) below the measured number, and the stated range ends below it.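

On the second core, methyl in place of hydrogen on the amide-type nitrogen again makes the compound a stronger inhibitor in this assay, with a 5.6-fold lower number from compound 2 to compound 4 (0.75 log units; beyond the scatter), so the direction of the step carries over from one core to the other. The size of the step does not carry over, and the gap is larger than repeated measurements would be expected to produce: the same change on two cores in this assay, a 30-fold lower number (1.48 log units; beyond the scatter) from compound 1 to compound 3 and a 5.6-fold lower number (0.75 log units; beyond the scatter) from compound 2 to compound 4, 5.3-fold (0.73 log units) apart, beyond the scatter of two such steps. Among the compounds shown here, this shows that a step measured on one core gives the likely direction on another but cannot be relied on for its size; with only two cores, it does not show which feature of a core sets that size or how the step would behave on a third core.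

The compounds shown leave open whether a larger group on the same nitrogen, such as ethyl or a longer chain, would continue this trend or reverse it. They also leave open whether a group carrying an amine or a carboxylic acid would be tolerated at that nitrogen on either core.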